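Halogen swap on the benzyl arm of a chalcone-triazole series

This account rests on a few compounds, and the source may have more. Where it says the series, first, only, none or still open, it means among the compounds named here.

Compound 2 `COc1ccc(C(=O)/C=C/c2ccc(OCc3cn(Cc4ccc(Br)cc4)nn3)cc2)cc1`: 8000 nM
Compound 1 `COc1ccc(C(=O)/C=C/c2ccc(OCc3cn(Cc4cccc(Br)c4)nn3)cc2)cc1`: 60000 nM

Among the compounds with values here, in a functional assay on HepG2 cells (Homo sapiens) for cytotoxicity, read by MTT assay, with a stated time of 48 h (on this read-out higher numbers stand for weaker inhibition and lower numbers for stronger inhibition), compound 2 gives 8000 nM, the lower of the two numbers in hand; in this assay compound 1 gives 60000 nM, and the step of a 7.5-fold lower number from compound 1 to compound 2 (0.88 log units; beyond the scatter) is the only measured comparison available. Compound 3 `COc1ccc(C(=O)/C=C/c2ccc(OCc3cn(Cc4cccc(F)c4)nn3)cc2)cc1` carries the change (3-fluorophenyl in place of 4-bromophenyl on a saturated chain carbon bound to an aromatic nitrogen), which returns the substituent to the position it holds in compound 1 while exchanging bromine for fluorine. Within the data shown here, the measured step bears on the positional part of this change and was beyond the scatter; the halogen exchange itself has no measured counterpart here. On that basis a higher number is expected for compound 3, though with wide uncertainty, so the step of a 3.1-fold higher number from compound 2 to compound 3 (0.49 log units; beyond the scatter) is estimated as a partial reversal of the earlier drop. Compound 3 is therefore expected to give about 25000 nM in this assay, within 8000 nM to 80000 nM.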

Compound 3, half-maximal inhibitory concentration: 85000 nM
Compound 3: the middle estimate sits 3.4-fold (0.53 log units) below what was measured, and the stated range ends below it.
By their numbers in this assay, from the lowest: compound 2; then compounds 1 and 3 (each within the scatter of the next).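

In this assay, fluoro in place of bromo on an aromatic carbon makes no readable difference between the two 3-halophenyl compounds (a 1.4-fold higher number from compound 1 to compound 3 (0.15 log units; within the scatter)). The large step (an 11-fold higher number from compound 2 to compound 3 (1.03 log units; beyond the scatter)) therefore sets compound 2 apart from both compound 1 and compound 3, so among these three the lower number goes only with the 4-bromophenyl group, and the choice of halogen on the 3-substituted ring does not register. No measurement at hand explains why the 4-bromophenyl group stands apart.

The compounds shown cannot separate the placement of the halogen from bromine itself, since a 4-fluorophenyl group would be needed for that comparison. From the compounds shown here alone, what an unsubstituted phenyl, a 4-chlorophenyl or a 4-methoxyphenyl group would give on the same saturated chain carbon also remains open.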